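Amide for Alkyl Chain on a Fatty Acid Receptor Agonist

The compounds below may be only part of what the source reports. "The series", "measured", "known", "first", "only" and "open" are said of these compounds alone.

Of the compounds shown here, three sharing a common acid-bearing core have been tested in a functional assay on cells for agonist activity at Free fatty acid receptor 1 (Homo sapiens), read by FLIPR and calcium flux, with a stated time of 60 min; a higher number here means a larger maximal response, a lower number a smaller maximal response. Compound 1 `COc1ccc(F)c(-c2ccc(COc3cccc([C@@H](CC(=O)O)C4CC4)c3)nc2CC(C)(C)C)c1` gives 66%. Compound 2 `COc1ccc(CCCC(C)(C)C)c(-c2ccc(COc3cccc(C(CC(=O)O)C4CC4)c3)cc2)c1` reaches 105%, and compound 3 `COc1ccc(CCC(C)(C)C)c(N2CCC(COc3cccc(C(CC(=O)O)C4CC4)c3)CC2)c1` reaches 110%. Compound 3 thus shows the highest of the three numbers, yet its nearest neighbour, compound 2, lies within the usual scatter of such measurements, so these two cannot be told apart; only compound 1 stands clearly lower, beyond the scatter.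

The next compound to consider is compound 4 `COc1ccc(C(=O)N(C)CC(C)(C)C)c(N2CCC(COc3cccc(C(CC(=O)O)C4CC4)c3)CC2)c1`, which has not yet been measured in this assay. It differs from compound 3 in a single place: methyl(neopentyl)carbamoyl in place of 3,3-dimethylbutyl on an aromatic carbon. A plain hydrocarbon chain is thus exchanged for a group containing an amide-type carbonyl and a nitrogen.

For the measured compounds named here, no pair of measured compounds differing in only one place is available, so there is no direct guide to how large a change at this position tends to be. Because compound 3 gives 110%, there is little room upward, and the expected step of a number 15 percentage points lower from compound 3 to compound 4 (beyond the scatter) is small, most likely within the scatter, with a downward drift somewhat more plausible than an upward one. Compound 4 is therefore estimated to reach 95%, with a range from 70% to 120%.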

Compound 4, largest response reached (Emax), in percent of the reference or control that the assay uses: 107%
Beside the measured number, compound 4's estimate is 12 percentage points below it; the range from low to high includes it.
By their numbers in this assay, from the lowest: compound 1; then compounds 2, 4 and 3 (each within the scatter of the next).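

In this assay, for the compounds shown here, placing methyl(neopentyl)carbamoyl instead of 3,3-dimethylbutyl on the aromatic carbon para to a methoxy group gives a number 3 percentage points lower from compound 3 to compound 4 (within the scatter), the first step between two compounds that differ in one place. The maximal responses of the two compounds cannot be told apart, so at this position a group of 9 heavy atoms with a carbonyl, a nitrogen and one hydrogen-bond acceptor does as well in this read-out as a hydrocarbon chain of 6 heavy atoms with no acceptor. Nothing in the data shown offers an explanation for this result.

This single step leaves open which parts of the new group matter, for example whether an amide hydrogen in place of the methyl on the nitrogen, or a longer chain on that nitrogen, would give a similar response. From the compounds shown here alone, it is also open whether a free amine or a carboxylic acid would be tolerated on the same aromatic carbon, and whether methyl(neopentyl)carbamoyl would behave the same way on the core of compound 2.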